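Cyclobutyl for Isopropyl on a Short-Lived Compound

The source may report more compounds than this note shows. Statements on the series, on what has been measured and on what is new or still open speak of the compounds shown alone.

Compound 1 `CCN1C[C@@H]2C[C@H]1CN2c1cc(F)c(-c2ccnc3c(-c4cccc5[nH]ncc45)c(-c4ccncc4)nn23)c(F)c1` gives 0.183 h
Compound 2 `CC(C)N1C[C@@H]2C[C@H]1CN2c1cc(F)c(-c2ccnc3c(-c4cccc5[nH]ncc45)c(-c4ccncc4)nn23)c(F)c1` gives 0.0833 h

In an in vitro ADME assay on microsomes from liver (Homo sapiens) for metabolic stability (a higher number here means that the compound lasts longer, a lower number that the compound disappears faster), compound 2 has the lower of the two numbers (0.0833 h). Compound 3 `Fc1cc(N2C[C@@H]3C[C@H]2CN3C2CCC2)cc(F)c1-c1ccnc2c(-c3cccc4[nH]ncc34)c(-c3ccncc3)nn12` carries cyclobutyl in place of isopropyl on an amine nitrogen in a ring. Among the measured compounds shown here, the only measured step that bears on this is a methyl added to the group on that same nitrogen (a 2.2-fold lower number from compound 1 to compound 2 (0.34 log units; beyond the scatter)), and it was modest. A similarly small change is therefore expected in this assay, with no clear direction and probably none beyond the scatter. The estimated step is small (a 1.2-fold higher number from compound 2 to compound 3 (0.08 log units; within the scatter)). Compound 3 is expected at 0.1 h (estimated range 0.05 h to 0.2 h).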

Compound 3, half-life: 0.05 h
Beside the measured number, compound 3's estimate is 2.0-fold (0.30 log units) above it; measured number inside the range.
By their numbers in this assay, from the lowest: compounds 3 and 2 (each within the scatter of the next); then compound 1.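

In this assay, cyclobutyl in place of isopropyl on this amine nitrogen gives a 1.7-fold lower number from compound 2 to compound 3 (0.22 log units; within the scatter) and so does not separate the two groups. Cyclobutyl in place of ethyl gives a 3.7-fold lower number from compound 1 to compound 3 (0.56 log units; beyond the scatter) and this leaves ethyl as the group with the highest number, clear of both others. Nothing measured here explains these numbers.

From the compounds shown here alone, it remains open whether methyl or a plain hydrogen on this nitrogen would lift the number above that of compound 1. The same question stands for an oxygen-containing ring such as oxetanyl.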